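Ring substituent steps toward compound 4

The compounds below may be only part of what the source reports. "The series", "measured", "known", "first", "only" and "open" are said of these compounds alone.

Measured compounds:
compound 1 `Nc1nc(NCc2ccccc2)nc(-c2ccccc2CO)n1` in a functional assay on cells for positive allosteric modulation of G-protein coupled receptor 68 (Homo sapiens), read by a luciferase reporter and cAMP accumulation, with a stated time of 30 min, at pH 6.8 and pH 8.3, in the presence of a further agent that is not named here; on this read-out lower numbers stand for lower potency and higher numbers for higher potency (the scale is a negative logarithm): 4.35
compound 2 `Nc1nc(NCc2cccc(F)c2)nc(-c2ccccc2CO)n1` in this assay: 4.52
compound 3 `Nc1nc(NCc2cccc(Cl)c2)nc(-c2ccccc2CO)n1` in this assay: 4.97

Compound 3 stands highest of the three numbers in this assay: a number 0.45 log units higher from compound 2 to compound 3 (beyond the scatter) and a number 0.62 log units higher from compound 1 to compound 3 (beyond the scatter), both beyond the scatter, whereas a number 0.17 log units higher from compound 1 to compound 2 (within the scatter) stays within it. Compound 4 `Nc1nc(NCc2cccc(C(F)(F)F)c2)nc(-c2ccccc2CO)n1` differs from compound 3 by trifluoromethyl in place of chloro on an aromatic carbon. The measured steps that bear on this change are the ones that altered the group on the same aromatic carbon, namely a number 0.62 log units higher from compound 1 to compound 3 (beyond the scatter), a number 0.45 log units higher from compound 2 to compound 3 (beyond the scatter) and a number 0.17 log units higher from compound 1 to compound 2 (within the scatter); two of them were modest rises and one lay within the scatter. Among the measured compounds shown here, no measured compound carries trifluoromethyl at this place, so the new step is only partly covered by the earlier ones. A small further rise, or no change beyond the scatter, is the expected outcome: the expected step is a number 0.18 log units higher from compound 3 to compound 4 (within the scatter). For compound 4 in this assay the estimate is 5.15, with a range from 4.65 to 5.65.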

Compound 4, negative logarithm of the antagonist equilibrium constant: 5.11
Compound 4: middle estimate off by 0.04 log units, on the high side; the range from low to high includes it.
By their numbers in this assay, from the lowest: compounds 1 and 2 (each within the scatter of the next); then compounds 3 and 4 (each within the scatter of the next).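

In this assay, among the compounds shown here, the exchange of chloro for trifluoromethyl, with 1 heavy atom leaving and 4 heavy atoms entering, gives a number 0.14 log units higher from compound 3 to compound 4 (within the scatter), so at this place, meta to a large group, the change in heavy atoms brings no step that can be separated from the scatter. Compared with the smaller substituents, trifluoromethyl gives a number 0.59 log units higher from compound 2 to compound 4 (beyond the scatter) and a number 0.76 log units higher from compound 1 to compound 4 (beyond the scatter), so compound 3 and compound 4 both stand clear of compound 1 and compound 2, although each step is only modest. No measurement shown here explains these steps.

On these data alone, it remains open whether a methoxy group, a nitrile, a carboxylic acid or a longer alkyl chain at this place would stay level with compound 3 and compound 4 or move away from them. As far as these compounds go, the effect of chloro or trifluoromethyl on other carbons of the same ring also remains open.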